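A few compounds are considered here, and "the series" means these few. Any claim that something is new, unique, unknown or untested is made for them only; others in the source may bear on it.

The three measured compounds share one core and differ only in the aryl group on the carbonyl carbon. Compound 1 `COc1ccc(-c2cc3ccccc3nc2/C=C/C(=O)c2ccc(O)cc2)cc1` gives 8970 nM in a functional assay on NCI-H1299 cells (Homo sapiens) for antiproliferative activity, read by XTT assay, with a stated time of 72 h (on this read-out lower numbers stand for stronger inhibition and higher numbers for weaker inhibition), the highest of the three numbers. Compound 2 `COc1ccc(-c2cc3ccccc3nc2/C=C/C(=O)c2ccc(OC)c(OC)c2)cc1` gives 1050 nM and compound 3 `COc1ccc(-c2cc3ccccc3nc2/C=C/C(=O)c2ccsc2)cc1` gives 1220 nM, and the two of them lie within the scatter of each other: a 1.2-fold higher number from compound 2 to compound 3 (0.07 log units; within the scatter).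

Compound 4 `COc1ccc(-c2cc3ccccc3nc2/C=C/C(=O)c2c[nH]c3ccccc23)cc1` is not yet measured. It carries the change (1H-indol-3-yl in place of 4-hydroxyphenyl on a carbonyl carbon).

Going by the values given here, two measured steps bear on this. Both replacements of the 4-hydroxyphenyl on the carbonyl carbon lowered the number well beyond the scatter: an 8.5-fold lower number from compound 1 to compound 2 (0.93 log units; beyond the scatter) and a 7.4-fold lower number from compound 1 to compound 3 (0.87 log units; beyond the scatter). The entering group differs from both of those, so the size of its effect is uncertain, but a step in the same direction is expected, since each departure from compound 1 so far has been favourable and of similar size. Compound 4 is therefore estimated at 1500 nM in this assay, within 500 nM to 5000 nM, which corresponds to an expected step of a 6.0-fold lower number from compound 1 to compound 4 (0.78 log units; beyond the scatter).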

Compound 4, half-maximal inhibitory concentration: > 10000 nM
Compound 4 was reported as a limit; the forecaster's own chance of this, stated with the estimate: 5%; at least 6.6-fold (0.82 log units) between middle value and limit.
By their numbers in this assay, from the lowest: compounds 2 and 3 (each within the scatter of the next); then compound 1. At a limit, above all of these: compound 4.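

In this assay compound 4 is reported as a limit and not as a number: the limit of > 10000 nM in this assay, at which 1 of the 4 values shown sits. The earlier compounds shown here showed only replacements of the 4-hydroxyphenyl on the carbonyl carbon that lowered the number, but here the step is an at least 1.1-fold higher number from compound 1 to compound 4 (0.04 log units; that floor lies within the scatter), so the gain seen with the other two replacements does not appear with 1H-indol-3-yl, though its floor does not separate compound 4 from compound 1. The position therefore does not reward every replacement, as the other two groups show with an at least 8.1-fold higher number from compound 3 to compound 4 (0.91 log units; beyond the scatter) and an at least 9.5-fold higher number from compound 2 to compound 4 (0.97 log units; beyond the scatter).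

The compounds shown leave open how far compound 4 lies past its limit, and so whether it truly differs from compound 1. Also open, as far as these compounds go, is how a plain phenyl or a naphthyl group on the carbonyl carbon would stand.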